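The source may report more compounds than this note shows. Statements on the series, on what has been measured and on what is new or still open speak of the compounds shown alone.

Compound 1 `Cc1ccc(NC(=O)CSc2snnc2-c2ccc(Cl)cc2Cl)c(Br)c1`: in an ADME assay on MT4 cells (Homo sapiens) for cytotoxicity (on this read-out lower numbers stand for higher toxicity in this test and higher numbers for lower toxicity in this test), compound 1 gives > 255000 nM, which is a limit of the assay rather than a number.
Compound 2 `COc1ccc(-c2nnsc2SCC(=O)Nc2ccc(C)cc2Br)cc1`: in this assay compound 2 gives 249000 nM.

Among the measured compounds shown here, compound 2 thus holds the only number so far; the other value is a limit. For the measured compounds named here, the one measured step gave an at least 1.0-fold lower number from compound 1 to compound 2 (0.01 log units; that floor lies within the scatter), with the limit of > 255000 nM in this assay, at which 1 of the 2 values shown sits, capping its size. Compound 3 `COc1ccc(-c2nnsc2SCC(=O)Nc2ccccc2[N+](=O)[O-])cc1` carries 2-nitrophenyl in place of 2-bromo-4-methylphenyl on an amide-type nitrogen. Going by the values given here, no measured step touches this part of the structure, and the only step seen stayed within the scatter. Compound 3 is therefore expected to give 200000 nM, between 70000 nM and 300000 nM. This expected step is a 1.2-fold lower number from compound 2 to compound 3 (0.10 log units; within the scatter).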

Compound 3, half-maximal cytotoxic concentration: >= 280000 nM
Compound 3 was reported as a limit; the forecaster's own chance of this, stated with the estimate: 40%; at least 1.4-fold (0.14 log units) between middle value and limit.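

The only change shown on the amide-type nitrogen, 2-nitrophenyl in place of 2-bromo-4-methylphenyl, gives in this assay an at least 1.1-fold higher number from compound 2 to compound 3 (0.05 log units; that floor lies within the scatter). At this place, then, the swap brings no sign of higher toxicity in this test, even though the entering group adds hydrogen-bond acceptors. Compound 3 stands at a limit of the assay and not at a number: the limit of >= 280000 nM in this assay, at which 1 of the 3 values shown sits. From the compounds shown here alone, whether a carboxylic acid or an amine in place of the 2-nitrophenyl group would move the read-out beyond the scatter stays open. So does the true size of this step.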